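This account rests on a few compounds, and the source may have more. Where it says the series, first, only, none or still open, it means among the compounds named here.

Measured in an ADME assay (liver) for metabolic stability, with Liver microsome (Rattus norvegicus) as the target, using microsomes and NADPH, with a stated time of 30 min, tested at 1 uM; a higher number here means faster removal of the compound, a lower number slower removal:
Compound 1 `CC(C)(C)n1cc(-c2cc(C(O)(C(F)(F)F)C(F)(F)F)cnc2N2CCN(S(=O)(=O)c3ccc(N)nc3)CC2)cn1`: 459 mL.min-1.g-1
Compound 2 `Cc1nc2cc(-c3cc(C(O)(C(F)(F)F)C(F)(F)F)cnc3N3CCN(S(=O)(=O)c4ccc(N)nc4)CC3)ccc2o1`: 99 mL.min-1.g-1

Compound 2 has the lower of the two numbers. Compound 3 `Nc1ccc(S(=O)(=O)N2CCN(c3ncc(C(O)(C(F)(F)F)C(F)(F)F)cc3-c3cccc4[nH]ncc34)CC2)cn1` differs from it in one place: 1H-indazol-4-yl in place of 2-methyl-1,3-benzoxazol-5-yl on an aromatic carbon. Within the data shown here, only one measured step bears on this: a 4.6-fold lower number from compound 1 to compound 2 (0.67 log units; beyond the scatter). That step was modest but beyond the scatter. Among the measured compounds shown here, it also brought in the group that now leaves, and no measured compound carries 1H-indazol-4-yl, so it gives no direction. No clear change is therefore expected in this assay. The expected step is a 1.2-fold lower number from compound 2 to compound 3 (0.09 log units; within the scatter). For compound 3 the estimated value is 80 mL.min-1.g-1, within an expected range of 30 mL.min-1.g-1 to 220 mL.min-1.g-1.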

Compound 3, intrinsic clearance in microsomes: 93 mL.min-1.g-1
Compound 3: the middle estimate sits 1.2-fold (0.07 log units) below what was measured, within the range that was stated.
By their numbers in this assay, from the lowest: compounds 3 and 2 (each within the scatter of the next); then compound 1.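

In this assay, placing 1H-indazol-4-yl instead of 2-methyl-1,3-benzoxazol-5-yl on this aromatic carbon gives a 1.1-fold lower number from compound 2 to compound 3 (0.03 log units; within the scatter), so the two groups cannot be told apart here. Replacing 1-(tert-butyl)-1H-pyrazol-4-yl with 1H-indazol-4-yl gives a 4.9-fold lower number from compound 1 to compound 3 (0.69 log units; beyond the scatter), so the earlier step is no longer the only one of its kind at this position. No measurement here explains these numbers. From the compounds shown here alone, it remains open whether a single phenyl ring, or a small group such as an amine, would give a number nearer compound 2 or compound 1.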